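The source may report more compounds than this note shows. Statements on the series, on what has been measured and on what is new or still open speak of the compounds shown alone.

For the measured compounds named here, compound 2 `COc1ccccc1-c1cn(C[C@H](O)[C@H]2OC(=O)C(OCc3ccccc3)=C2OCc2ccccc2)nn1` is the lower of the two numbers so far in an ADME assay on HFF cells (Homo sapiens) for cytotoxicity, read by MTT assay, with a stated time of 72 h; on this read-out lower numbers stand for stronger inhibition and higher numbers for weaker inhibition: compound 2 gives 50 nM, while compound 1 `O=C1O[C@H]([C@@H](O)Cn2cc(-c3cccc(O)c3)nn2)C(OCc2ccccc2)=C1OCc1ccccc1` gives 39000 nM. Going by the values given here, the only measured step between them, a 780-fold lower number from compound 1 to compound 2 (2.89 log units; beyond the scatter), shows that a change at this position of the shared core can move the read-out a long way. Compound 3 `O=C1O[C@H]([C@@H](O)Cn2cc(CNS(=O)(=O)c3ccc(F)cc3)nn2)C(OCc2ccccc2)=C1OCc1ccccc1` carries a further change at the same position: (((4-fluorophenyl)sulfonyl)amino)methyl in place of 2-methoxyphenyl on an aromatic carbon. Among the compounds with values here, no measured step covers this replacement, so the step from compound 1 to compound 2 is the only guide; it tells how far this position can swing, but not in which direction a sulfonamide-bearing group will move the number. Since the group that gave the low number in compound 2 is removed entirely, the number for compound 3 is expected to rise, by a step estimated as a 100-fold higher number from compound 2 to compound 3 (2.00 log units; beyond the scatter), though with wide uncertainty. For compound 3 the value in this assay is therefore estimated at 5000 nM, with a range from 400 nM to 50000 nM.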

Compound 3, half-maximal inhibitory concentration: 30 nM
Estimate against measurement, compound 3: 170-fold (2.22 log units) above; the measured number lies below the stated range.
By their numbers in this assay, from the lowest: compounds 3 and 2 (each within the scatter of the next); then compound 1.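

In this assay, placing (((4-fluorophenyl)sulfonyl)amino)methyl on the aromatic carbon in place of 2-methoxyphenyl gives a 1.7-fold lower number from compound 2 to compound 3 (0.22 log units; within the scatter), so the low number at this position is not tied to 2-methoxyphenyl, and a group with a different make-up, carrying a sulfonyl and a hydrogen-bond donor, reads the same within the scatter. Measured against 3-hydroxyphenyl, the same group gives a 1300-fold lower number from compound 1 to compound 3 (3.11 log units; beyond the scatter), which leaves compound 1 as the only one of the three with a high number and shows that the large swing at this position is reached by two different replacements of 3-hydroxyphenyl, not by one alone. Nothing available bears on why these groups give these numbers.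

The compounds shown leave open what in 3-hydroxyphenyl goes with the high number of compound 1, which plain phenyl, 3-methoxyphenyl or 2-hydroxyphenyl at the same carbon could separate. They also leave open which part of the new group matters, which a simple aminomethyl, a carboxamide in place of the sulfonamide or a phenyl without the fluorine could address.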